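Fluoro to Methyl: One Atom Changed, Potency Estimated

A few compounds are considered here, and "the series" means these few. Any claim that something is new, unique, unknown or untested is made for them only; others in the source may bear on it.

Of the compounds shown here, three sharing one core have been tested in a functional assay on MCF7 cells (Homo sapiens) for inhibition, read by MTT assay, with a stated time of 72 h; on this read-out lower numbers stand for stronger inhibition and higher numbers for weaker inhibition. Compound 1 `COc1ccc(Nc2nc(SCc3cn(Cc4ccccc4Cl)nn3)nc(-c3ccccc3)c2C#N)cc1` gives 8050 nM. Compound 2 `N#Cc1c(Nc2ccccc2Cl)nc(SCc2cn(Cc3ccccc3Cl)nn2)nc1-c1ccccc1` gives 1950 nM, and compound 3 `N#Cc1c(Nc2ccc(F)cc2)nc(SCc2cn(Cc3ccccc3Cl)nn2)nc1-c1ccccc1` gives 19900 nM. Compound 3 carries the highest number of the three: the steps of a 2.5-fold higher number from compound 1 to compound 3 (0.39 log units; beyond the scatter) and a 10-fold higher number from compound 2 to compound 3 (1.01 log units; beyond the scatter) both lie beyond the scatter, so compound 3 is the weakest inhibitor among them in this assay.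

Compound 4 `Cc1ccc(Nc2nc(SCc3cn(Cc4ccccc4Cl)nn3)nc(-c3ccccc3)c2C#N)cc1` has not yet been measured. It differs from compound 3 in one place: methyl in place of fluoro on an aromatic carbon. The change sits on the (4-fluorophenyl)amino group, para to a large group, and turns it into a (4-methylphenyl)amino group.

Going by the values given here, only one measured step touches this position: a 2.5-fold higher number from compound 1 to compound 3 (0.39 log units; beyond the scatter), where a methoxy rather than a fluoro stood in the same place. Among the compounds with values here, no step with a methyl there has been measured. The step of a 10-fold higher number from compound 2 to compound 3 (1.01 log units; beyond the scatter) changes a different place and a different group, so it speaks less directly. Because a 2.5-fold higher number from compound 1 to compound 3 (0.39 log units; beyond the scatter) shows that replacing the fluoro at this place by another group gave a lower number, a modest fall is expected for compound 4 in this assay, with caution since methyl and methoxy are not the same group. Compound 4 is expected to give 10000 nM in this assay, within 4000 nM to 30000 nM. The estimated step is therefore a 2.0-fold lower number from compound 3 to compound 4 (0.30 log units; within the scatter).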

Compound 4, half-maximal inhibitory concentration: 9420 nM
The estimate for compound 4 lay 1.1-fold (0.03 log units) above the measured number; measured number inside the range.
By their numbers in this assay, from the lowest: compound 2; then compounds 1 and 4 (each within the scatter of the next); then compound 3.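

In this assay, a 2.1-fold lower number from compound 3 to compound 4 (0.32 log units; beyond the scatter) gives this position a second measured replacement for fluoro: until now only methoxy had been compared with it, and methyl also gives a lower number. The comparison between the two replacements, a 1.2-fold higher number from compound 1 to compound 4 (0.07 log units; within the scatter), lies within the scatter, so this assay does not separate methyl from methoxy at this place, and among the three groups tried here only fluoro stands apart, with the highest number. The change of the whole aryl group still counts for more, as a 4.8-fold higher number from compound 2 to compound 4 (0.68 log units; beyond the scatter) shows that the 4-methylphenyl group in compound 4 leaves a higher number than the 2-chlorophenyl group in compound 2, which keeps the lowest number of the four.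

No measurement shown here explains why fluoro differs from methyl and methoxy at this place, so the numbers describe the trend without giving its cause. The compounds shown leave open how a chloro, an amine or a carboxylic acid at this place would compare, and whether a methyl moved to the position that the chloro occupies in compound 2 would bring the number down as well.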